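Swapping cyclohexyl for 4-methylphenyl at the amide alpha carbon

A few compounds are considered here, and "the series" means these few. Any claim that something is new, unique, unknown or untested is made for them only; others in the source may bear on it.

Compound 1 `CC1CCN(c2nc(C(F)(F)F)ccc2CNC(=O)C(c2ccc(NS(C)(=O)=O)c(F)c2)C2CCCCC2)CC1` is measured in an assay on CHO cells for antagonist activity at transient receptor potential cation channel subfamily V member 1 (Homo sapiens), read by FLIPR (a higher number here means a weaker inhibitor, a lower number a stronger inhibitor), where compound 1 gives 31.1 nM. Compound 3 `CS(=O)(=O)Nc1ccc(C(C(=O)NCc2ccc(C(F)(F)F)nc2SC2CCCCC2)c2ccc(F)cc2)cc1F` gives 37.6 nM and compound 2 `CS(=O)(=O)Nc1ccc(C(C(=O)NCc2ccc(C(F)(F)F)nc2SC2CCCCC2)c2cccc(F)c2)cc1F` gives 48.7 nM, so all three numbers sit together, with no gap beyond the scatter. For the measured compounds named here, the one single-point step among them, a 1.3-fold lower number from compound 2 to compound 3 (0.11 log units; within the scatter), changes only the position of fluorine on a phenyl ring. Compound 4 `Cc1ccc(C(C(=O)NCc2ccc(C(F)(F)F)nc2N2CCC(C)CC2)c2ccc(NS(C)(=O)=O)c(F)c2)cc1` differs from compound 1 by 4-methylphenyl in place of cyclohexyl on a saturated chain carbon bound to an aromatic carbon and a carbonyl carbon. Going by the values given here, no measured step exchanges a saturated ring for an aromatic one at that carbon, and compounds 2 and 3 carry an aromatic group there together with a different core substituent, so they only show that aryl groups at this position give numbers near compound 1. Compound 4 is therefore expected to give 40 nM, between 15 nM and 110 nM, a step of a 1.3-fold higher number from compound 1 to compound 4 (0.11 log units; within the scatter) that is expected to stay within the scatter.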

Compound 4, inhibition constant: 1.1 nM
Estimate against measurement, compound 4: 36-fold (1.56 log units) above; measured number outside the range, below it.
By their numbers in this assay, from the lowest: compound 4; then compounds 1, 3 and 2 (each within the scatter of the next).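

At the saturated chain carbon bound to an aromatic carbon and a carbonyl carbon, 4-methylphenyl in place of cyclohexyl is the first change shown to move the number in this assay beyond the scatter, with a 28-fold lower number from compound 1 to compound 4 (1.45 log units; beyond the scatter) on the core of compound 1. This position therefore responds strongly to the group it carries, a result the fluorine shift on the phenyl ring gave no sign of. Nothing measured here accounts for the step. Going by these compounds, it remains open whether plain phenyl would give a number like that of compound 4, and whether a chlorine in place of the methyl or a pyridine ring in place of the phenyl ring would keep it.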